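Adding an Amino Group to Compound 1

This account rests on a few compounds, and the source may have more. Where it says the series, first, only, none or still open, it means among the compounds named here.

Compound 1, `ClCc1ccc(Cn2cnc3c(Cl)ncnc32)cc1`: "not determined" (no result reported)
Compound 2, `ClCc1cccc(Cn2cnc3c(Cl)nc(Cl)nc32)c1`: 4460 nM
Compound 3, `Nc1nc(Cl)c2ncn(Cc3ccccc3CCl)c2n1`: 83200 nM

Compound 1 gives no single number in a functional assay on T47D cells (Homo sapiens) for cytotoxicity, read by sulforhodamine B assay, with a stated time of 48 h (on this read-out higher numbers stand for weaker inhibition of growth and lower numbers for stronger inhibition of growth), so it stands nowhere on the scale; compound 2 and compound 3 give numbers, with compound 3 reaching total growth inhibition only at a far higher concentration than compound 2. Compound 4, `Nc1nc(Cl)c2ncn(Cc3ccc(CCl)cc3)c2n1`, differs from compound 1 by amino in place of hydrogen on an aromatic carbon. With no number for compound 1, the size of the step in this assay cannot be stated; only the values of compound 2 and compound 3 offer a frame, and the value of compound 3 suggests a weak inhibitor. Compound 4 is expected to reach total growth inhibition near 30000 nM, within 8000 nM to 120000 nM.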

Compound 4, concentration for total growth inhibition: 39800 nM
The estimate for compound 4 lay 1.3-fold (0.12 log units) below the measured number; measured number inside the range.
By their numbers in this assay, from the lowest: compound 2; then compound 4; then compound 3.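

In this assay, among the compounds shown here, compound 1 gives "not determined" (no result reported) and compound 4 gives 39800 nM, so no step between them can be read. The compounds shown leave open how far amino in place of hydrogen shifts total growth inhibition. Nothing at hand explains the value of compound 4.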